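Series notes: cyclohexyloxy in place of 1-acetylpiperidin-4-yl

The source may hold more compounds than are shown below. What is called first, only, known or untested is meant among the compounds shown, and "the series" means these compounds.

Measured so far:
compound 1 `CCNC(=O)Nc1sc2ccccc2c1C(=O)N1CCN(C2CCN(C(=O)C3CCN(C(C)=O)CC3)CC2)CC1`: "not determined" (no result reported)
compound 2 `CCNC(=O)Nc1sc2ccccc2c1C(=O)N1CCN(C2CCN(C(=O)C(C)(C)C)CC2)CC1`: 450 nM

In a functional assay on HepG2 cells (Homo sapiens) for inhibition, read by scintillation counting, with a stated time of 2 h (a higher number here means a weaker inhibitor, a lower number a stronger inhibitor), compound 2 gives 450 nM. Compound 1 stands without a number in this assay, so nothing sizes a step away from it. Compound 3 `CCNC(=O)Nc1sc2ccccc2c1C(=O)N1CCN(C2CCN(C(=O)OC3CCCCC3)CC2)CC1` carries the change (cyclohexyloxy in place of 1-acetylpiperidin-4-yl on a carbonyl carbon). Within the data shown here, no step between measured compounds covers this change; the expectation in this assay is a shift no larger than the usual scatter, with no clear direction, anchored on the value of compound 2. Compound 3 is expected at 400 nM, with a range from 120 nM to 1300 nM.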

Compound 3, half-maximal inhibitory concentration: 635 nM
Estimate against measurement, compound 3: 1.6-fold (0.20 log units) below, and the stated range covers the measured number.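

In this assay cyclohexyloxy in place of tert-butyl on a carbonyl carbon gives a 1.4-fold higher number from compound 2 to compound 3 (0.15 log units; within the scatter) and so does not separate the two groups: this position carries either one without a step beyond the scatter. The step from compound 1 cannot be read, and 1-acetylpiperidin-4-yl remains unsized at this carbonyl carbon. Nothing available explains the result. As far as these compounds go, whether an amine or a carboxylic acid on this carbonyl carbon would give a step beyond the scatter stays open.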